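Chloro for fluoro on the thiourea aryl ring

The source may report more compounds than this note shows. Statements on the series, on what has been measured and on what is new or still open speak of the compounds shown alone.

Measured compounds in a functional assay on PC-3 cells (Homo sapiens) for antiproliferative activity, read by MTT assay; on this read-out higher numbers stand for weaker inhibition and lower numbers for stronger inhibition:
compound 1 `CNC(=O)c1ccc(Oc2cccc(NC(=S)Nc3ccc(Br)c(C(F)(F)F)c3)c2)nc1` 2670 nM
compound 2 `CNC(=O)c1ccc(Oc2cccc(NC(=S)Nc3ccc(F)c(F)c3)c2)nc1` 23100 nM
compound 3 `CNC(=O)c1ccc(Oc2cccc(NC(=S)Nc3ccc(Cl)c(C(F)(F)F)c3)c2)nc1` 1980 nM

Compound 2 gives the highest number of the three; compound 1 and compound 3 both sit far lower, beyond the scatter. Compound 4 `CNC(=O)c1ccc(Oc2cccc(NC(=S)Nc3ccc(F)c(Cl)c3)c2)nc1` has not yet been measured. It differs from compound 2 in one place: chloro in place of fluoro on an aromatic carbon, ortho to a fluoro group and meta to a large group, turning the 3,4-difluorophenyl into a 3-chloro-4-fluorophenyl.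

Among the measured compounds shown here, only one measured step touches a halogen swap on this ring, a 1.3-fold lower number from compound 1 to compound 3 (0.13 log units; within the scatter), and it exchanges bromo for chloro at the other position, so it speaks only weakly to the present change. For the measured compounds named here, the gap between compound 2 and compound 1 and compound 3 suggests that compounds with a larger group on this ring reach lower numbers, but no measured pair isolates chloro against fluoro. In this assay compound 4 is therefore expected to lie below compound 2, and its estimate is 6500 nM with a range of 2500 nM to 16000 nM, that is an expected step of a 3.6-fold lower number from compound 2 to compound 4 (0.55 log units; beyond the scatter).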

Compound 4, half-maximal inhibitory concentration: 18400 nM
The estimate for compound 4 lay 2.8-fold (0.45 log units) below the measured number; measured number above the stated range.
By their numbers in this assay, from the lowest: compounds 3 and 1 (each within the scatter of the next); then compounds 4 and 2 (each within the scatter of the next).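

Among the compounds shown here, this pair is the first to isolate chloro against fluoro at this carbon, with the rest of the molecule held fixed. In this assay the swap gives a 1.3-fold lower number from compound 2 to compound 4 (0.10 log units; within the scatter) and so leaves the 3,4-difluorophenyl and the 3-chloro-4-fluorophenyl compounds indistinguishable on this read-out, which means that a chloro here, on its own, does not reproduce the far lower numbers of compound 1 and compound 3. Nothing available explains why this exchange leaves the number where it is.

The compounds shown do not separate the two places in which compound 1 and compound 3 differ from compound 2, so a trifluoromethyl on this carbon with the fluoro group kept remains an open case. On these data alone, how a methoxy group or an amine on this carbon would read in this assay also stays unknown.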